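The source may report more compounds than this note shows. Statements on the series, on what has been measured and on what is new or still open speak of the compounds shown alone.

The series shares one core; compound 1 `Cc1cc(SC(C)(C)C)c(S(C)(=O)=O)cc1C(=O)N=C(N)N` carries a (tert-butyl)sulfanyl group, compound 2 `COc1cc(C)c(C(=O)N=C(N)N)cc1S(C)(=O)=O` a methoxy group, and compound 3 `Cc1cc(Oc2ccccc2Cl)c(S(C)(=O)=O)cc1C(=O)N=C(N)N` a 2-chlorophenoxy group at the same aromatic carbon. In a functional assay for inhibition of sodium/hydrogen exchanger (Oryctolagus cuniculus) (a lower number here means a stronger inhibitor, a higher number a weaker inhibitor), compound 1 gives 22 nM, compound 2 gives 16 nM, and compound 3 gives 14 nM. Compound 3 holds the lowest of the three numbers, yet a 1.1-fold lower number from compound 2 to compound 3 (0.06 log units; within the scatter) and a 1.6-fold lower number from compound 1 to compound 3 (0.20 log units; within the scatter) are both within the scatter, as is a 1.4-fold lower number from compound 1 to compound 2 (0.14 log units; within the scatter); none of the three separates from the others.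

Compound 4 `Cc1cc(-n2ccnc2)c(S(C)(=O)=O)cc1C(=O)N=C(N)N` is the next variation at that carbon: 1H-imidazol-1-yl in place of 2-chlorophenoxy on an aromatic carbon. Among the compounds with values here, the steps that bear on this change are the two exchanges at the same position, from (tert-butyl)sulfanyl to 2-chlorophenoxy and from methoxy to 2-chlorophenoxy, each within the scatter, so the position has so far accepted different groups without a step beyond the scatter. No five-membered aromatic ring with hetero atoms has yet stood there, so the expectation rests on that tolerance alone. In this assay compound 4 is therefore expected to show a 1.4-fold higher number from compound 3 to compound 4 (0.15 log units; within the scatter), a step not beyond the scatter. The estimate for compound 4 is 20 nM, ranging from 7 nM to 60 nM, the range widened for the untried ring.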

Compound 4, half-maximal inhibitory concentration: 23 nM
The estimate for compound 4 lay 1.2-fold (0.06 log units) below the measured number; measured number inside the range.
By their numbers in this assay, from the lowest: compounds 3, 2, 1 and 4 (each within the scatter of the next).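

In this assay the first five-membered aromatic ring with hetero atoms at this carbon, 1H-imidazol-1-yl, stays within the scatter of all three earlier groups: a 1.6-fold higher number from compound 3 to compound 4 (0.22 log units; within the scatter), a 1.4-fold higher number from compound 2 to compound 4 (0.16 log units; within the scatter) and a 1.0-fold higher number from compound 1 to compound 4 (0.02 log units; within the scatter). The tolerance at this position therefore now covers a group joined through a ring nitrogen as well as groups joined through oxygen or sulfur, and the exchange of 2-chlorophenoxy for 1H-imidazol-1-yl shows that replacing a six-membered aromatic ring of carbon only with a five-membered ring carrying 2 hetero atoms, and going from 1 hydrogen-bond acceptor to 2, produces no step beyond the scatter. Nothing at hand gives a reason for this flat response.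

With all four groups inside the scatter of one another, the compounds shown mark no boundary to what this carbon accepts, and no group here separates from the rest. From the compounds shown here alone, whether a primary amine, a carboxylic acid or a longer chain such as n-butoxy at this carbon would give a step beyond the scatter remains open.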